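A few compounds are considered here, and "the series" means these few. Any claim that something is new, unique, unknown or untested is made for them only; others in the source may bear on it.

Working notes on the series, read in a functional assay on DU-145 cells (Homo sapiens) for cytotoxicity, read by sulforhodamine B assay, with a stated time of 48 h; a lower number here means a stronger inhibitor, a higher number a weaker inhibitor. Compound 3 (`C[C@H]1CC[C@@H]2[C@@H](OC(=O)[C@]23CC(c2ccccc2)=NO3)[C@]2(C)C(=O)C=C[C@@]12O`), with an unsubstituted phenyl, gives 39800 nM. Compound 1 (`COc1ccc(C2=NO[C@]3(C2)C(=O)O[C@@H]2[C@H]3CC[C@H](C)[C@]3(O)C=CC(=O)[C@@]23C)cc1`), the 4-methoxyphenyl member, gives 20000 nM, and compound 2 (`C[C@H]1CC[C@@H]2[C@@H](OC(=O)[C@]23CC(c2ccccc2Br)=NO3)[C@]2(C)C(=O)C=C[C@@]12O`), the 2-bromophenyl member, gives 18000 nM. Compound 3 therefore stands level with compound 1 within the scatter and modestly on the weaker side of compound 2. All three numbers sit close together, as a 1.1-fold lower number from compound 1 to compound 2 (0.05 log units; within the scatter) also shows.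

Compound 4 (`C[C@H]1CC[C@@H]2[C@@H](OC(=O)[C@]23CC(c2ccc(O)cc2)=NO3)[C@]2(C)C(=O)C=C[C@@]12O`) differs from compound 3 by one change: hydroxy in place of hydrogen on an aromatic carbon, that is, phenyl to 4-hydroxyphenyl. Among the compounds with values here, no measured compound carries a hydroxy group, so the reading is indirect. Compound 1 is the closest match, and its step of a 2.0-fold higher number from compound 1 to compound 3 (0.30 log units; within the scatter) stays within the scatter. Compound 2 has its group elsewhere on the ring, and its step of a 2.2-fold higher number from compound 2 to compound 3 (0.34 log units; beyond the scatter) is only modest. On these two steps, a small move towards a lower number is expected for the new group, with nothing beyond the scatter. The expected step is a 1.4-fold lower number from compound 3 to compound 4 (0.15 log units; within the scatter). For compound 4 the estimated value in this assay is 28000 nM, with an expected range of 12000 nM to 60000 nM.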

Compound 4, half-maximal inhibitory concentration: 93000 nM
Compound 4: middle estimate off by 3.3-fold (0.52 log units), on the low side; the measured number lies above the stated range.
By their numbers in this assay, from the lowest: compounds 2, 1 and 3 (each within the scatter of the next, the first and the last beyond it); then compound 4.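

In this assay, hydroxy in place of hydrogen on this aromatic carbon, para to a large group, gives a 2.3-fold higher number from compound 3 to compound 4 (0.37 log units; beyond the scatter), a step beyond the scatter, whereas the methoxy member, compound 1, stands level with compound 3 within the scatter. The oxygen at this position therefore does not read the same with and without its methyl: hydrogen in place of methyl gives a 4.7-fold higher number from compound 1 to compound 4 (0.67 log units; beyond the scatter), the larger of the two steps at this position, so a free hydroxy and a methoxy are not interchangeable here. The exchange of 2-bromophenyl for 4-hydroxyphenyl gives a 5.2-fold higher number from compound 2 to compound 4 (0.71 log units; beyond the scatter), which, with the two steps above, puts compound 4 on the weaker side of all three other compounds, each by a step beyond the scatter.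

Nothing at hand bears on the origin of this shift. Whether the higher number is particular to hydroxy stays open, as the compounds shown include no amine or carboxylic acid para to the large group, no longer chain than methyl on the oxygen, and no hydroxy at another place on the phenyl.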